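This account rests on a few compounds, and the source may have more. Where it says the series, first, only, none or still open, it means among the compounds named here.

Measured so far:
compound 1 `O=C1NCCN1c1ccc(S(=O)(=O)Nc2ccc3[nH]ccc3c2)cc1` — 130 nM
compound 2 `CCCCCCCc1ccc(NS(=O)(=O)c2ccc(N3CCNC3=O)cc2)cc1` — > 1000 nM
compound 3 `CC(C)(C)c1cc(NS(=O)(=O)c2ccc(N3CCNC3=O)cc2)cc(C(C)(C)C)c1` — > 1000 nM

In a functional assay on HT-29 cells (Homo sapiens) for antiproliferative activity, read by sulforhodamine B assay, with a stated time of 48 h (a higher number here means a weaker inhibitor, a lower number a stronger inhibitor), compound 1 gives 130 nM. Compound 2 returns only a limit, > 1000 nM, not a number. Compound 3 also reaches only a limit, > 1000 nM. Compound 2 thus stands at the weak end of what has been measured, at the limit of > 1000 nM in this assay, at which 2 of the 3 values shown sit, together with compound 3, while compound 1 alone carries a numerical value.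

Compound 4 `COc1ccc(NS(=O)(=O)c2ccc(N3CCNC3=O)cc2)cc1` has not yet been tested in this assay. It differs from compound 2 in one place: methoxy in place of heptyl on an aromatic carbon. With compound 2 known only as a limit, the step can only be guessed. Compound 4 is expected to move toward stronger inhibition by an at least 2.5-fold lower number from compound 2 to compound 4 (0.39 log units; beyond the scatter), a step that may exceed the scatter. Compound 4 is estimated at 400 nM, within 100 nM to 2000 nM.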

Compound 4, half-maximal inhibitory concentration: 800 nM
Compound 4: middle estimate off by 2.0-fold (0.30 log units), on the low side; the range from low to high includes it.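

In this assay compound 4, with methoxy on this aromatic carbon, gives 800 nM, a numerical value at a place where heptyl gave none. Compound 2 remains a limit, not a number: the limit of > 1000 nM in this assay, at which 2 of the 4 values shown sit. Methoxy in place of heptyl therefore gives an at least 1.2-fold lower number from compound 2 to compound 4 (0.09 log units; that floor lies within the scatter), so a real gain is possible but not established.

Open, on these data alone, is how an amine, a carboxylic acid or a propyl chain would read on this carbon. Also open, as far as these compounds go, is how far compound 2 truly lies from compound 4.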